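From 3,5-difluorophenyl to 4-fluorophenyl

The source may report more compounds than this note shows. Statements on the series, on what has been measured and on what is new or still open speak of the compounds shown alone.

In a functional assay on MIA PaCa-2 cells (Homo sapiens) for inhibition, read by MTT assay, with a stated time of 48 h, tested at 10 uM (a higher number here means more inhibition of growth at the concentration tested, a lower number less inhibition of growth), compound 1 (`Cc1oc2c([C@H]3CCN(C)C[C@H]3O)c(O)cc(O)c2c(=O)c1C(O)c1c(Cl)cccc1Cl`) gives 0% of growth inhibition. Compound 2 (`Cc1oc2c([C@H]3CCN(C)C[C@H]3O)c(O)cc(O)c2c(=O)c1C(O)c1cc(F)cc(F)c1`) gives 6% and stands level with compound 1 within the scatter. Compound 3 (`Cc1oc2c([C@H]3CCN(C)C[C@H]3O)c(O)cc(O)c2c(=O)c1C(O)c1ccc(F)cc1`) has not yet been measured. It carries 4-fluorophenyl in place of 3,5-difluorophenyl on a saturated chain carbon bound to an aromatic carbon and an oxygen on a saturated carbon. Among the measured compounds shown here, one measured step bears on this change, because the same carbon exchanged its aryl group in a number 6 percentage points higher from compound 1 to compound 2 (within the scatter) and 3,5-difluorophenyl replaced 2,6-dichlorophenyl there. For the measured compounds named here, with only that step to go on, no change beyond the scatter is expected in this assay for the new exchange. The expected step is no change at the digits printed from compound 2 to compound 3 (within the scatter) and would stay within the scatter. Compound 3 is estimated at 6% (expected range 0% to 18%).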

Compound 3, percent growth inhibition at one concentration: 17%
Compound 3: the middle estimate sits 11 percentage points below what was measured; low and high end bracket the measured number.
By their numbers in this assay, from the lowest: compounds 1 and 2 (each within the scatter of the next); then compound 3.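

In this assay, among the compounds shown here, the aryl group on this carbon now registers for the first time: the step of a number 11 percentage points higher from compound 2 to compound 3 (beyond the scatter) goes with 4-fluorophenyl replacing 3,5-difluorophenyl, and the step of a number 17 percentage points higher from compound 1 to compound 3 (beyond the scatter) goes with 4-fluorophenyl replacing 2,6-dichlorophenyl. Compound 1 and compound 2 had stayed level within the scatter, so this position is not indifferent to its aryl group, although both new steps are modest. Nothing measured here explains the result.

This exchange alters the number of fluorine atoms and their placing together, and the compounds shown do not separate the two. They also leave open how an unsubstituted phenyl, a 4-chlorophenyl or a 4-methoxyphenyl would read on this carbon.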